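Urea in place of amide on a shared pyrazole core

The compounds below may be only part of what the source reports. "The series", "measured", "known", "first", "only" and "open" are said of these compounds alone.

Measured compounds:
compound 1, `O=C(Nc1cccc(-n2cc(-c3ccncc3)c(-c3ccc(Cl)c(O)c3)n2)c1)Nc1ccc(Cl)c(Cl)c1`, 1490 nM
compound 2, `COc1cc(-c2nn(-c3cccc(NC(=O)c4ccc(Cl)c(C(F)(F)F)c4)c3)cc2-c2ccncc2)ccc1Cl`, 4860 nM

Of the compounds shown here, two have been measured in a functional assay on SF-268 cells (Homo sapiens) for inhibition, read by sulforhodamine B assay, with a stated time of 48 h; a lower number here means a stronger inhibitor of growth, a higher number a weaker inhibitor of growth. Compound 1 gives 1490 nM, and compound 2 gives 4860 nM, the higher of the two numbers; the gap to compound 1 lies beyond the scatter. Compound 3, `COc1cc(-c2nn(-c3cccc(NC(=O)Nc4cccc(C(F)(F)F)c4)c3)cc2-c2ccncc2)ccc1Cl`, has not yet been measured. It differs from compound 2 in one place: (3-(trifluoromethyl)phenyl)amino in place of 4-chloro-3-(trifluoromethyl)phenyl on a carbonyl carbon. Among the measured compounds shown here, compound 1 and compound 2 differ in several places at once, so no step between measured compounds isolates this change, and what the gap between them shows cannot be assigned to the carbonyl substituent alone. For compound 3 a modest step downward in this assay is expected, a 1.6-fold lower number from compound 2 to compound 3 (0.21 log units; within the scatter), since compound 1, which also carries an amino group on the carbonyl carbon, gives 1490 nM. The estimate for compound 3 is 3000 nM, within 1200 nM to 8000 nM.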

Compound 3, concentration for 50% growth inhibition: 1360 nM
Beside the measured number, compound 3's estimate is 2.2-fold (0.34 log units) above it, and the stated range covers the measured number.
By their numbers in this assay, from the lowest: compounds 3 and 1 (each within the scatter of the next); then compound 2.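

In this assay, replacing 4-chloro-3-(trifluoromethyl)phenyl with (3-(trifluoromethyl)phenyl)amino on a carbonyl carbon gives a 3.6-fold lower number from compound 2 to compound 3 (0.55 log units; beyond the scatter). This single-place step shows that this position alone can move the number beyond the scatter, which the gap between compound 1 and compound 2, differing in several places at once, could not show. No measurement here explains the step.

The change adds an amino nitrogen with its hydrogen-bond donor and also removes the 4-chloro group, so the compounds shown leave open which of the two accounts for the step. Also open, from the compounds shown here alone, is how this position would respond to a cyclohexylamino or a morpholine group on the same carbonyl carbon.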